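Trifluoroethoxy in place of trifluoromethyl: lipophilicity note

The compounds below may be only part of what the source reports. "The series", "measured", "known", "first", "only" and "open" are said of these compounds alone.

Compound 2 `Oc1ccc(/C=C/c2ccc(/C=C/c3ccc(O)cc3)c(C(F)(F)F)c2)cc1` carries two hydroxyphenyl-ethenyl arms on its central ring together with a trifluoromethyl group. In a physicochemical assay for lipophilicity, read by HPLC (on this read-out lower numbers stand for lower lipophilicity and higher numbers for higher lipophilicity), compound 2 gives 5.64. Going by the values given here, this is the only numerical value in hand for the series; the other value is a limit. Compound 1 `COc1cc(/C=C/c2ccc(OC(F)(F)F)cc2)ccc1/C=C/c1ccc(OC(F)(F)F)cc1` reaches only a limit of this assay, > 7, and no number is known for it. The series thus sits with one number and one limit, as summed up by the limit of > 7 in this assay, at which 1 of the 2 values shown sits. Among the compounds with values here, no measured step exists between compound 1 and compound 2, so nothing beyond what the two values show can be said about their gap.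

Compound 3 `Oc1ccc(/C=C/c2ccc(/C=C/c3ccc(O)cc3)c(OCC(F)(F)F)c2)cc1` differs from compound 2 by 2,2,2-trifluoroethoxy in place of trifluoromethyl on an aromatic carbon. Within the data shown here, no measured step of this kind is in hand for the series. The change is expected to move this assay upward by a small step, of a size close to the scatter, a number 0.26 log units higher from compound 2 to compound 3 (within the scatter). Compound 3 is accordingly estimated at 5.9, with a range from 5.4 to 6.5.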

Compound 3, partition coefficient: 5.25
Estimate against measurement, compound 3: 0.65 log units above; the measured number lies below the stated range.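

In this assay, going by these compounds alone, the first measured step at this position, on the aromatic carbon ortho to a 2-(4-hydroxyphenyl)ethenyl group and meta to a second such group, points downward: 2,2,2-trifluoroethoxy in place of trifluoromethyl gives a number 0.39 log units lower from compound 2 to compound 3 (beyond the scatter). The change adds heavy atoms and a hydrogen-bond acceptor, yet the read-out falls, so in this pair a larger substituent does not go with a higher number. No measurement in hand bears on the cause of this step.

As far as these compounds go, whether a methoxy group, an amine or a carboxylic acid on the same aromatic carbon would also fall below compound 2 remains open, as does the question of whether the ether oxygen or the fluorinated chain of 2,2,2-trifluoroethoxy goes with the step. A single pair also leaves open whether the same exchange would give a step of this direction and size at another position on the ring or on another core.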